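Replacing the bromo group of compound 3 with hydroxy

The compounds below may be only part of what the source reports. "The series", "measured", "known", "first", "only" and "open" are said of these compounds alone.

In a functional assay on A549 cells (Homo sapiens) for antiproliferative activity, read by MTT assay, with a stated time of 72 h (a lower number here means a stronger inhibitor, a higher number a weaker inhibitor), compound 1 (`O=C(N/N=C/c1ccc(Br)cc1)Nc1ccc(Oc2ccnc3[nH]ccc23)c(F)c1`) gives 820 nM, compound 2 (`O=C(N/N=C/c1ccc(F)cc1Cl)Nc1ccc(Oc2ccnc3[nH]ccc23)c(F)c1`) gives 10 nM and compound 3 (`O=C(N/N=C/c1ccc(Br)cc1)Nc1ccc(Oc2ccnc3[nH]ccc23)cc1`) gives 640 nM. Compound 3 therefore sits level with compound 1 at the high end of these numbers, since the swap of fluoro for hydrogen, a 1.3-fold lower number from compound 1 to compound 3 (0.11 log units; within the scatter), stays within the scatter. Compound 2 lies far lower than both.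

Compound 4 (`O=C(N/N=C/c1ccc(O)cc1)Nc1ccc(Oc2ccnc3[nH]ccc23)cc1`) has hydroxy in place of bromo on an aromatic carbon, para to a large group: hydroxy in place of bromo on an aromatic carbon. The fluoro step does not touch this group. For the measured compounds named here, the only measured change to the 4-bromophenyl group, an 82-fold lower number from compound 1 to compound 2 (1.91 log units; beyond the scatter), shows that this end can move the number strongly. However, it introduces different groups and gives no direction for hydroxy. No clear step beyond the scatter is therefore expected in this assay, though the uncertainty is wide in both directions. The estimated step is a 1.1-fold lower number from compound 3 to compound 4 (0.03 log units; within the scatter). For compound 4 the expected value is 600 nM, with an estimated range of 100 nM to 3000 nM.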

Compound 4, half-maximal inhibitory concentration: 1910 nM
Beside the measured number, compound 4's estimate is 3.2-fold (0.50 log units) below it; the measured number falls inside the stated range.
By their numbers in this assay, from the lowest: compound 2; then compounds 3 and 1 (each within the scatter of the next); then compound 4.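

In this assay, the single-atom change from 4-bromophenyl to 4-hydroxyphenyl gives a 3.0-fold higher number from compound 3 to compound 4 (0.47 log units; beyond the scatter), so this position, para to a large group, responds to one substituent swap alone. For the compounds shown here, the only earlier change at this end, an 82-fold lower number from compound 1 to compound 2 (1.91 log units; beyond the scatter), replaced the whole 2-chloro-4-fluorophenyl group and moved the number down, whereas hydroxy moves it up, so this end of the series can shift in either direction. No evidence here accounts for the effect of hydroxy.

Open, from the compounds shown here alone, is whether the higher number belongs to hydroxy alone or would also follow from methoxy or an amine at the same place, and whether it would carry over to the fluoro-bearing core of compound 1. Also open, going by these compounds, is how much of the drop to compound 2 belongs to its chloro and how much to its fluoro.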